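Swapping an ethyl ester for an acid on a leukotriene ligand

The source may report more compounds than this note shows. Statements on the series, on what has been measured and on what is new or still open speak of the compounds shown alone.

Of the compounds shown here, three have been tested in an assay on isolated protein for binding affinity to cysteinyl leukotriene receptor 1 (Cavia porcellus), tested at 10 uM; a higher number here means more inhibition at the concentration tested (going by the name of the read-out), a lower number less inhibition. Compound 1, `c1cc(OCCCc2nnn[nH]2)cc(OCc2cnc3ccccc3c2)c1`, gives 15% in this assay. Compound 2, `c1ccc(COc2cccc(OCCCc3nnn[nH]3)c2)cc1`, gives 12%. Compound 3, `CCOC(=O)c1ccc(COc2ccc(OCCCc3nnn[nH]3)cc2)nc1`, gives 35%, which is the highest of the three numbers; it sits beyond the usual scatter above compound 1 and likewise beyond the scatter above compound 2. Compound 1 and compound 2 lie within the scatter of each other, so nothing can be said about an order between them.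

The next compound, compound 4, `O=C(O)c1ccc(COc2ccc(OCCCc3nnn[nH]3)cc2)nc1`, has not yet been measured. It differs from compound 3 in one place only: hydrogen in place of ethyl on an oxygen next to a carbonyl group. Going by the values given here, no pair among the measured compounds shows this same change, so there is no earlier step of this kind to lean on, and the expectation rests on compound 3 alone.

Given that compound 3 already stands highest with 35%, the step from compound 3 to compound 4 in this assay is expected to be a modest rise, a number 10 percentage points higher from compound 3 to compound 4 (within the scatter), close to the edge of the scatter rather than far beyond it. Compound 4 is therefore estimated to give 45% in this assay, with a plausible range from 20% to 70%.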

Compound 4, a percentage reported as inhibition, at one concentration (the size of the read-out at that concentration, not a potency): 30%
The estimate for compound 4 lay 15 percentage points above the measured number, within the range that was stated.
By their numbers in this assay, from the lowest: compounds 2 and 1 (each within the scatter of the next); then compounds 4 and 3 (each within the scatter of the next).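

Swapping ethyl for hydrogen on the oxygen next to a carbonyl group makes no readable difference in this assay (a number 5 percentage points lower from compound 3 to compound 4 (within the scatter)). Going by these compounds alone, this is the first single change seen, and it shows that, at this one concentration, the ethoxycarbonyl and carboxy forms cannot be told apart, so the ethyl part of the ester is not needed to keep the reading at this level. No measurement at hand explains why the number stays within the scatter.

As far as these compounds go, whether other groups in this place, such as a primary amide, a methyl ester or an ester with a longer chain, would give a different number remains open. From the compounds shown here alone, since each reading comes from a single concentration, the potency of compound 3 and compound 4 also remains open.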